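Amide variation in the series: estimate for compound 4

The source may hold more compounds than are shown below. What is called first, only, known or untested is meant among the compounds shown, and "the series" means these compounds.

Compound 3 `CN1[C@@H]2c3[nH]c4ccccc4c3C[C@H]1[C@H](C#N)N1[C@@H](CNC(=O)c3cc4ccccc4s3)c3[nH]c4ccccc4c3C[C@@H]21` has the highest number of the three measured compounds in a functional assay on HepG2 cells (Homo sapiens) for cytotoxicity, read by MTT assay, with a stated time of 72 h; on this read-out higher numbers stand for weaker inhibition and lower numbers for stronger inhibition: compound 3 gives 300 nM, against 210 nM for compound 2 `CN1[C@@H]2c3[nH]c4ccccc4c3C[C@H]1[C@H](C#N)N1[C@@H](CNC(=O)c3ccc(F)cc3)c3[nH]c4ccccc4c3C[C@@H]21` and 20 nM for compound 1 `CN1[C@@H]2c3[nH]c4ccccc4c3C[C@H]1[C@H](C#N)N1[C@@H](CN3C(=O)c4ccccc4C3=O)c3[nH]c4ccccc4c3C[C@@H]21`. The steps from compound 1 to the two amides are large: an 11-fold higher number from compound 1 to compound 2 (1.02 log units; beyond the scatter) and a 15-fold higher number from compound 1 to compound 3 (1.18 log units; beyond the scatter). Between the two amides, however, the exchange of the group on the carbonyl carbon hardly moves the number: a 1.4-fold higher number from compound 2 to compound 3 (0.15 log units; within the scatter).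

Compound 4 `COc1ccc(/C=C/C(=O)NC[C@H]2c3[nH]c4ccccc4c3C[C@H]3[C@H]4c5[nH]c6ccccc6c5C[C@@H]([C@H](C#N)N23)N4C)cc1` keeps the amide and changes only the group on the carbonyl carbon: 2-(4-methoxyphenyl)ethenyl in place of 1-benzothiophen-2-yl on a carbonyl carbon. For the measured compounds named here, only the step from compound 2 to compound 3 bears on this kind of change, and it stayed within the scatter. Going by the values given here, no measured pair shows what an ethenyl-linked aromatic group does at this position. The expectation is therefore that compound 4 differs little from compound 3, with the estimated step of no change at the digits printed from compound 3 to compound 4 (within the scatter) lying within the scatter. Among the compounds with values here, for compound 4 in this assay the estimated value is 300 nM, with a range from 120 nM to 750 nM; the range is kept wide because the single bearing step a 1.4-fold higher number from compound 2 to compound 3 (0.15 log units; within the scatter) rests on one pair alone.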

Compound 4, half-maximal inhibitory concentration: 2140 nM
Compound 4: the middle estimate sits 7.1-fold (0.85 log units) below what was measured; measured number outside the range, above it.
By their numbers in this assay, from the lowest: compound 1; then compounds 2 and 3 (each within the scatter of the next); then compound 4.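

Working notes on the amide position: in this assay the group on the carbonyl carbon is not indifferent, since the exchange to 2-(4-methoxyphenyl)ethenyl gives a 7.1-fold higher number from compound 3 to compound 4 (0.85 log units; beyond the scatter) and also a 10-fold higher number from compound 2 to compound 4 (1.01 log units; beyond the scatter) in the same series. The earlier exchange, a 1.4-fold higher number from compound 2 to compound 3 (0.15 log units; within the scatter) for 1-benzothiophen-2-yl in place of 4-fluorophenyl, therefore does not describe the whole position: two groups joined directly to the carbonyl carbon through an aromatic ring stay within the scatter of each other, while the group entering here lies beyond the scatter of both. Nothing at hand gives a reason for this step.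

The compounds shown leave open whether the step goes with the ethenyl link or with the methoxy group, a question that 4-methoxyphenyl directly on the carbonyl carbon, 2-phenylethenyl, and the saturated 2-(4-methoxyphenyl)ethyl would separate. They also leave open how a carboxylic acid or a dimethylamino group on the phenyl ring of the entering group would read in this assay on this carbonyl carbon.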